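Filling a Methyl Hydrogen on a Ubiquitin Hydrolase Inhibitor

The compounds below may be only part of what the source reports. "The series", "measured", "known", "first", "only" and "open" are said of these compounds alone.

Of the compounds shown here, three have been measured in an assay on isolated protein for inhibition of ubiquitin carboxyl-terminal hydrolase 7 (Homo sapiens), read by fluorescence, with stated times of 30 min and 1 h; on this read-out higher numbers stand for weaker inhibition and lower numbers for stronger inhibition. Compound 1 `O=C1CCC(=O)N1Cc1cc2nccc(-c3cc(Cl)cc4c3O[C@@H](c3ocnc3CN3CCC3)C4)c2s1` gives 13 nM, compound 2 `Cc1cc(Cl)cc(-c2ccnc3cc(CN4C(=O)C5CC5C4=O)sc23)c1C[C@@H]1CNC[C@@H](C)O1` gives 0.39 nM, and compound 3 `Cc1cc2nccc(-c3cc(Cl)cc4c3O[C@@H](C(=O)N3CCNCC3)C4)c2s1` gives 130 nM, the highest of the three numbers and therefore the weakest inhibitor shown. The unmeasured compound 4 `O=C([C@H]1Cc2cc(Cl)cc(-c3ccnc4cc(Cn5cnccc5=O)sc34)c2O1)N1CCNCC1` departs from compound 3 by one change: a group of 7 heavy atoms (4 carbon, 2 nitrogen, 1 oxygen; one six-membered aromatic ring with 2 hetero atoms) in place of a hydrogen atom, on a saturated chain carbon bound to an aromatic carbon. Going by the values given here, compounds 1 and 2 differ from compound 3 in more than one place, so no single step between measured compounds is available, but both carry larger substituents and both sit well beyond the scatter below compound 3. A sizeable gain is therefore expected, with an estimated step of a 13-fold lower number from compound 3 to compound 4 (1.11 log units; beyond the scatter) in this assay. Compound 4 is estimated at 10 nM, within a range from 2 nM to 50 nM.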

Compound 4, half-maximal inhibitory concentration: 27 nM
For compound 4 the middle estimate is 2.7-fold (0.43 log units) below the measured one; the measured number falls inside the stated range.
By their numbers in this assay, from the lowest: compound 2; then compound 1; then compound 4; then compound 3.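

Replacing a hydrogen atom on this saturated chain carbon with a six-membered aromatic ring with 2 hetero atoms gives a 4.8-fold lower number from compound 3 to compound 4 (0.68 log units; beyond the scatter) in this assay for the whole change. This is the only single-place comparison shown, and it indicates that, on the core of compound 3, this position tolerates a group of 7 heavy atoms and that inhibition strengthens modestly, beyond the scatter. No measurement here explains the gain. Still open, as far as these compounds go, is whether a plain phenyl ring or a simple amine on this carbon would match this ring, and so whether its nitrogens or carbonyl matter.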